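From a methylpiperidine to a methylimidazole

The compounds below may be only part of what the source reports. "The series", "measured", "known", "first", "only" and "open" are said of these compounds alone.

In an ADME assay on BaF3 cells (Mus musculus) for antiproliferative activity, read by CCK-8 assay, with a stated time of 72 h (on this read-out lower numbers stand for stronger inhibition of growth and higher numbers for weaker inhibition of growth), compound 1 `O=C(CCSc1ccc2c(/C=C/c3ccccn3)n[nH]c2c1)Nc1ccc(F)c(C(F)(F)F)c1` gives 610 nM, while compound 2 `CC1CCN(Cc2ccc(NC(=O)CCSc3ccc4c(/C=C/c5ccccn5)n[nH]c4c3)cc2C(F)(F)F)CC1` gives 4170 nM, the higher of the two numbers. Compound 3 `Cc1cn(Cc2ccc(NC(=O)CCSc3ccc4c(/C=C/c5ccccn5)n[nH]c4c3)cc2C(F)(F)F)cn1` carries 4-methyl-1H-imidazol-1-yl in place of 4-methylpiperidin-1-yl on a saturated chain carbon bound to an aromatic carbon. Among the compounds with values here, no measured step covers this exchange. Within the data shown here, the only guide to size is the modest 6.8-fold higher number from compound 1 to compound 2 (0.83 log units; beyond the scatter), which lies beyond the scatter and followed a different change. A smaller move toward lower numbers is therefore expected in this assay, an estimated 1.7-fold lower number from compound 2 to compound 3 (0.22 log units; within the scatter). For compound 3 the estimate is 2500 nM, with an expected range of 800 nM to 7000 nM.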

Compound 3, concentration for 50% growth inhibition: 1990 nM
Estimate against measurement, compound 3: 1.3-fold (0.10 log units) above; the measured number falls inside the stated range.
By their numbers in this assay, from the lowest: compound 1; then compound 3; then compound 2.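

In this assay the exchange on this saturated chain carbon gives a 2.1-fold lower number from compound 2 to compound 3 (0.32 log units; beyond the scatter) and so shows that the group placed here does shift growth inhibition, even with the rest of the molecule unchanged. Yet a 3.3-fold higher number from compound 1 to compound 3 (0.51 log units; beyond the scatter) remains, so the 4-methyl-1H-imidazol-1-yl regains only part of the ground lost relative to the fluoro compound. No evidence is available to explain this shift. Going by these compounds, how a morpholine or an imidazole without its methyl would read on this same carbon stays open.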